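Piperazine nitrogen substituent scan toward compound 4

A few compounds are considered here, and "the series" means these few. Any claim that something is new, unique, unknown or untested is made for them only; others in the source may bear on it.

Measured so far:
Compound 1 `CN(C[C@H]1Cc2c(cccc2N2CCN(Cc3ccccn3)CC2)CN1)[C@H]1CCCc2cccnc21` gives 4.47 nM in a functional assay on CCRF-CEM cells for antagonist activity at C-X-C chemokine receptor type 4 (Homo sapiens), read by calcium flux, with stated times of 25 min and 90 s; on this read-out lower numbers stand for stronger inhibition and higher numbers for weaker inhibition.
Compound 2 `CN(C[C@H]1Cc2c(cccc2N2C[C@@H]3C[C@H]2CN3)CN1)[C@H]1CCCc2cccnc21` gives 146 nM in this assay.
Compound 3 `CC(C)N1CCN(c2cccc3c2C[C@H](CN(C)[C@H]2CCCc4cccnc42)NC3)CC1` gives 16.9 nM in this assay.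

Compound 3 holds the second highest of the three numbers. Its nearest neighbour is compound 1: a 3.8-fold higher number from compound 1 to compound 3 (0.58 log units; beyond the scatter). Its furthest is compound 2: an 8.6-fold lower number from compound 2 to compound 3 (0.94 log units; beyond the scatter).

Compound 4 `CN1CCN(c2cccc3c2C[C@H](CN(C)[C@H]2CCCc4cccnc42)NC3)CC1` differs from compound 3 only at the ring nitrogen: methyl in place of isopropyl on an amine nitrogen in a ring. The change is thus 4-isopropylpiperazin-1-yl to 4-methylpiperazin-1-yl.

Among the compounds with values here, of the measured steps, only the one from compound 1 to compound 3 touches the same ring nitrogen, and it was modest: a 3.8-fold higher number from compound 1 to compound 3 (0.58 log units; beyond the scatter). The step from compound 2 to compound 3 concerns a different part of the molecule and does not bear on this change. Within the data shown here, no measured pair shows methyl against isopropyl on that nitrogen, so the direction cannot be read from the data. Given that the one relevant step was modest, the expected movement in this assay is small, likely within the scatter, with a slight lean toward a higher number.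

Compound 4 is therefore estimated at 22 nM, with a range from 8 nM to 60 nM. The expected step reads a 1.3-fold higher number from compound 3 to compound 4 (0.11 log units; within the scatter).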

Compound 4, half-maximal inhibitory concentration: 29.6 nM
Compound 4: the middle estimate sits 1.3-fold (0.13 log units) below what was measured; low and high end bracket the measured number.
By their numbers in this assay, from the lowest: compound 1; then compounds 3 and 4 (each within the scatter of the next); then compound 2.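

In this assay, methyl in place of isopropyl on the ring nitrogen gives a 1.8-fold higher number from compound 3 to compound 4 (0.24 log units; within the scatter) and so adds a second small alkyl group that cannot be told apart from isopropyl at this position. The (pyridin-2-yl)methyl group of compound 1 now stands apart from both small alkyl groups, with a 6.6-fold higher number from compound 1 to compound 4 (0.82 log units; beyond the scatter) as its direct comparison with methyl, while a 4.9-fold lower number from compound 2 to compound 4 (0.69 log units; beyond the scatter) shows that 4-methylpiperazin-1-yl also keeps a lower number than the two-ring group of compound 2. Nothing available bears on the reason for these steps.

The compounds shown leave open whether the lower number of compound 1 depends on the pyridine ring nitrogen or only on an aromatic ring at this position. A benzyl group on the same ring nitrogen would separate those two readings, and a hydroxyethyl chain there would extend the scan beyond alkyl and pyridinylmethyl groups.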